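One amide aryl swap in a three-compound series

The compounds below may be only part of what the source reports. "The series", "measured", "known", "first", "only" and "open" are said of these compounds alone.

Compound 1 `NC(=O)c1c(NC(=O)c2ccccc2F)sc2c1CCN(Cc1c(Cl)cccc1Cl)C2`: 10300 nM
Compound 2 `NC(=O)c1c(NC(=O)c2ccccc2F)sc2c1CCN(C(=S)Nc1ccccc1Cl)C2`: 12500 nM
Compound 3 `NC(=O)c1c(NC(=O)c2ccccc2F)sc2c1CCN(C(=O)Nc1ccccc1Cl)C2`: 32700 nM

In a functional assay on HL-60 cells (Homo sapiens) for antiproliferative activity, with a stated time of 24 h (on this read-out lower numbers stand for stronger inhibition and higher numbers for weaker inhibition), compound 2 gives 12500 nM, the second highest of the three numbers. Its nearest neighbour is compound 1, where a 1.2-fold higher number from compound 1 to compound 2 (0.08 log units; within the scatter) lies within the scatter; its furthest is compound 3, reached by a 2.6-fold higher number from compound 2 to compound 3 (0.42 log units; beyond the scatter). Compound 4 `Cc1ccc(C(=O)Nc2sc3c(c2C(N)=O)CCN(C(=S)Nc2ccccc2Cl)C3)cc1` differs from compound 2 by 4-methylphenyl in place of 2-fluorophenyl on a carbonyl carbon. For the measured compounds named here, all three measured steps, including a 3.2-fold higher number from compound 1 to compound 3 (0.50 log units; beyond the scatter), change only the group on the amine nitrogen in the ring; none of them touches the aryl on the carbonyl carbon, so no measured step bears directly on this change. The observed steps were modest at most, and the series as a whole spans a narrow band. Compound 4 is therefore expected to stay close to compound 2, with a step of no change at the digits printed from compound 2 to compound 4 (within the scatter) in this assay, meaning no change beyond the scatter. The estimate for compound 4 is 12500 nM, within a range from 5000 nM to 32000 nM.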

Compound 4, half-maximal inhibitory concentration: 8430 nM
Estimate against measurement, compound 4: 1.5-fold (0.17 log units) above; low and high end bracket the measured number.
By their numbers in this assay, from the lowest: compounds 4, 1 and 2 (each within the scatter of the next); then compound 3.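

For the compounds shown here, this is the first measured change on the aryl on the carbonyl carbon. In this assay, with the group on the amine nitrogen in the ring kept as in compound 2, 4-methylphenyl in place of 2-fluorophenyl gives a step that stays within the scatter (a 1.5-fold lower number from compound 2 to compound 4 (0.17 log units; within the scatter)), so this one exchange of aryl groups leaves no readable change in antiproliferative activity. Nothing shown explains this result or says what either aryl group contributes.

The compounds shown leave open whether this exchange would also stay within the scatter with the group on the amine nitrogen of compound 1 or compound 3. They also leave open whether an aminophenyl or carboxyphenyl group, or a longer alkyl chain, on this carbonyl carbon would shift the number beyond the scatter.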